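This account rests on a few compounds, and the source may have more. Where it says the series, first, only, none or still open, it means among the compounds named here.

Notes on the series, read in a physicochemical assay for solubility, read by HPLC, using the shake flask method, with a stated time of 2 h, at pH 2; a lower number here means a less soluble compound, a higher number a more soluble compound. Compound 1 `Nc1ncc(-c2ccc(C(=O)N3CC(O)C3)cc2)nc1-c1ccc(C(F)(F)F)cc1` gives 110000 nM, compound 2 `Nc1ncc(-c2ccc(C(=O)N3CCC(N)CC3)cc2)nc1-c1ccc(C(F)(F)F)cc1` gives 200000 nM, and compound 3 `Nc1ncc(-c2ccc(C(=O)N3CC[C@@H](O)C3)cc2)nc1-c1ccc(C(F)(F)F)cc1` gives 103000 nM. Compound 3 thus stands within the scatter of both other compounds, and the three numbers form a single group.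

Compound 4 `Nc1ncc(-c2ccc(C(=O)N3CC[C@H](O)C3)cc2)nc1-c1ccc(C(F)(F)F)cc1` is the next to be read, and its structure relates to that of compound 3 as follows: the two compounds have the same atoms and bonds and differ only in configuration as drawn: 1 of 1 stereo elements differ; a stereocentre at a saturated ring carbon is drawn R in compound 3 and S in compound 4. For the measured compounds named here, no measured step tests a change of configuration alone. Going by the values given here, the only steps that bear on it are exchanges of the group on the carbonyl carbon: a 1.1-fold lower number from compound 1 to compound 3 (0.03 log units; within the scatter), a 1.8-fold higher number from compound 1 to compound 2 (0.26 log units; within the scatter) and a 1.9-fold lower number from compound 2 to compound 3 (0.29 log units; within the scatter). All three lie within the scatter, although each replaces atoms and bonds, which the step to compound 4 does not.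

No step beyond the scatter is therefore expected, in either direction, and the expected step is a 1.0-fold higher number from compound 3 to compound 4 (0.01 log units; within the scatter). For compound 4 the estimated value is 105000 nM, with an expected range of 60000 nM to 180000 nM.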

Compound 4, solubility: 93000 nM
For compound 4 the middle estimate is 1.1-fold (0.05 log units) above the measured one; low and high end bracket the measured number.
By their numbers in this assay, from the lowest: compounds 4, 3, 1 and 2 (each within the scatter of the next, the first and the last beyond it).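

In this assay, for the compounds shown here, there is a 1.1-fold lower number from compound 3 to compound 4 (0.04 log units; within the scatter), so the drawn configuration at the saturated ring carbon of the 3-hydroxypyrrolidin-1-yl group leaves no readable mark on this number, and the step can be read as one of configuration alone: the fact that compounds 3 and 4 differ only in the configuration as drawn. 3-Hydroxypyrrolidin-1-yl in place of 4-aminopiperidin-1-yl gives a 2.2-fold lower number from compound 2 to compound 4 (0.33 log units; beyond the scatter), the only step beyond the scatter and a modest one. The same group in place of 3-hydroxyazetidin-1-yl gives a 1.2-fold lower number from compound 1 to compound 4 (0.07 log units; within the scatter), so these two groups are not told apart here.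

From the compounds shown here alone, compounds 3 and 4 stand within the scatter of each other, so it remains open whether 4-aminopiperidin-1-yl truly separates from the hydroxylated groups. Also open, going by these compounds, is where a carboxylic acid or a morpholin-4-yl group on the carbonyl carbon would fall.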